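Trimethoxyphenyl Analogue of a Sulfonamide Pyrazoline Series

The source may hold more compounds than are shown below. What is called first, only, known or untested is meant among the compounds shown, and "the series" means these compounds.

Of the compounds shown here, two have been measured. Compound 1 `Cc1cc(O)c(C2=NN(c3ccc(S(N)(=O)=O)cc3)C(c3ccccc3O)C2)cc1Cl` carries a 2-hydroxyphenyl group on a saturated ring carbon, and in a functional assay on MDA-MB-435 cells (Homo sapiens) for antiproliferative activity, with a stated time of 48 h (a lower number here means a stronger inhibitor of growth, a higher number a weaker inhibitor of growth), compound 1 gives 2040 nM. Compound 2 `COc1ccc(C2CC(c3cc(Cl)c(C)cc3O)=NN2c2ccc(S(N)(=O)=O)cc2)cc1OC` carries a 3,4-dimethoxyphenyl group at that position instead; in this assay compound 2 gives 3970 nM. Going by the values given here, the single step between them, a 1.9-fold higher number from compound 1 to compound 2 (0.29 log units; within the scatter), lies within the scatter, so the two values cannot be ordered. Compound 2 therefore stands at the higher of two numbers that are, for practical purposes, indistinguishable.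

Compound 3 `COc1ccc(C2CC(c3cc(Cl)c(C)cc3O)=NN2c2ccc(S(N)(=O)=O)cc2)c(OC)c1OC` is the next compound to be measured. It differs from compound 2 by a single change: methoxy in place of hydrogen on an aromatic carbon. Among the compounds with values here, no measured step in this set concerns adding a methoxy group to an aromatic carbon, and the one step that is available, a 1.9-fold higher number from compound 1 to compound 2 (0.29 log units; within the scatter), shows that a substantial change of the same aryl group left the number within the scatter. On that basis compound 3 is expected to give 4500 nM in this assay, with a range from 1800 nM to 11000 nM, a step of a 1.1-fold higher number from compound 2 to compound 3 (0.05 log units; within the scatter) that is expected to stay within the scatter.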

Compound 3, concentration for 50% growth inhibition: 2570 nM
For compound 3 the middle estimate is 1.8-fold (0.24 log units) above the measured one, and the stated range covers the measured number.
By their numbers in this assay, from the lowest: compounds 1, 3 and 2 (each within the scatter of the next).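

In this assay, going by these compounds alone, the change from 3,4-dimethoxyphenyl to 2,3,4-trimethoxyphenyl gives a 1.5-fold lower number from compound 2 to compound 3 (0.19 log units; within the scatter) and so provides the first reading for methoxy in place of hydrogen on an aromatic carbon of this aryl group, here ortho to a large group and ortho to a methoxy group. The comparison with the 2-hydroxyphenyl group gives a 1.3-fold higher number from compound 1 to compound 3 (0.10 log units; within the scatter) and adds a second large change of the group on this saturated ring carbon that stays within the scatter, so the three aryl groups shown at this position cannot be ordered by their numbers. The data hold no measurement that could explain these numbers, and no separate finding bears on them.

Going by these compounds, it remains open whether any other group on this saturated ring carbon would give a step beyond the scatter, for example an aryl group carrying an amine or a carboxylic acid, or one with ethoxy or a longer chain in place of methoxy. The three compounds also share the rest of the core, so they say nothing about how changes elsewhere in it would read in this assay or whether the aryl group would then matter more.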